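Swapping propyl for cyclohexyl on a bicyclic ether

A few compounds are considered here, and "the series" means these few. Any claim that something is new, unique, unknown or untested is made for them only; others in the source may bear on it.

Compound 1 `CCC[C@H]1C[C@@](C)(O)[C@@H]2CC[C@@H](C)C[C@H]2O1` was tested in an ADME assay on MDCK cells (Canis lupus familiaris) for cytotoxicity, read by MTT assay, with a stated time of 48 h; a higher number here means that more compound is tolerated, a lower number that less compound is tolerated. For compound 1 only a limit of the assay is known, > 1320000 nM, so its true value is open. It sits at the limit of > 1320000 nM in this assay, at which 1 of the 2 values shown sits. A second compound, compound 2 `C[C@@H]1CC[C@@H]2[C@H](C1)OC1(CCCCCCC1)C[C@@]2(C)O`, gives 379000 nM in this assay. Compound 3 `C[C@@H]1CC[C@@H]2[C@@H](C1)O[C@@H](C1CCCCC1)C[C@@]2(C)O` has not yet been measured. It differs from compound 1 by cyclohexyl in place of propyl on a saturated ring carbon. For the measured compounds named here, no measured pair shows this change, so its effect is uncertain. Compound 3 is expected to be tolerated somewhat less, a step of an at least 2.6-fold lower number from compound 1 to compound 3 (0.42 log units; beyond the scatter). Compound 3 is estimated at 500000 nM, between 150000 nM and 1500000 nM.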

Compound 3, half-maximal cytotoxic concentration: 24200 nM
For compound 3 the middle estimate is 21-fold (1.32 log units) above the measured one, and the stated range ends above it.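

Cyclohexyl in place of propyl on this saturated ring carbon, next to the ring oxygen, sharply lowers the amount of compound tolerated: an at least 54-fold lower number from compound 1 to compound 3 (1.73 log units; beyond the scatter). For the compounds shown here, this is the first pair to show that the cells respond strongly to the group at this position. Going by these compounds, compound 1 stands at a limit of the assay, so the true size of the step stays open: the limit of > 1320000 nM in this assay, at which 1 of the 3 values shown sits. The compounds shown do not separate the effect of having a ring from that of having more carbon. On these data alone, a longer chain such as hexyl could help tell these apart, and how an amine here would behave remains unknown.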